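This account rests on a few compounds, and the source may have more. Where it says the series, first, only, none or still open, it means among the compounds named here.

Compound 1 `OC1C[C@@H]2CCCC[C@@H]2[C@H]1/C=C/c1ccc(-c2cccc(F)c2)cn1` gives 220 nM in an assay on cell membranes for displacement of a labelled ligand from proteinase-activated receptor 1 (Homo sapiens), read by scintillation counting, with a stated time of 60 min; on this read-out higher numbers stand for weaker inhibition and lower numbers for stronger inhibition. Compound 2 `COC1C[C@@H]2CCCC[C@@H]2[C@H]1/C=C/c1ccc(-c2cccc(F)c2)cn1` gives 67 nM in this assay, and compound 3 `NC1C[C@@H]2CCCC[C@@H]2[C@H]1/C=C/c1ccc(-c2cccc(F)c2)cn1` gives 230 nM in this assay. Compound 3 thus holds the highest number of the three, though compound 1 sits within the scatter of it, while compound 2 is set apart by a 3.4-fold higher number from compound 2 to compound 3 (0.54 log units; beyond the scatter). Compound 4 `CCOC(=O)NC1C[C@@H]2CCCC[C@@H]2[C@H]1/C=C/c1ccc(-c2cccc(F)c2)cn1` carries ethoxycarbonyl in place of hydrogen on an amine nitrogen. For the measured compounds named here, the one measured step that places a group on the hydroxyl or amine is a 3.3-fold lower number from compound 1 to compound 2 (0.52 log units; beyond the scatter), and a 3.4-fold higher number from compound 2 to compound 3 (0.54 log units; beyond the scatter) runs the same way back. For compound 4 a modest lowering of the number is therefore expected, a 1.9-fold lower number from compound 3 to compound 4 (0.28 log units; within the scatter), with the caution that ethoxycarbonyl is larger than anything measured here. Compound 4 is estimated at 120 nM in this assay, within a range from 40 nM to 400 nM.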

Compound 4, half-maximal inhibitory concentration: 2000 nM
Estimate against measurement, compound 4: 17-fold (1.22 log units) below, and the stated range ends below it.
By their numbers in this assay, from the lowest: compound 2; then compounds 1 and 3 (each within the scatter of the next); then compound 4.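

On the saturated ring carbon, a group placed on the heteroatom does not lower the number as a rule in this assay: methyl on the oxygen gave a 3.3-fold lower number from compound 1 to compound 2 (0.52 log units; beyond the scatter), while ethoxycarbonyl on the amine nitrogen gave an 8.7-fold higher number from compound 3 to compound 4 (0.94 log units; beyond the scatter). The (ethoxycarbonyl)amino group also stands apart from the other groups at this place, with a 30-fold higher number from compound 2 to compound 4 (1.47 log units; beyond the scatter) and a 9.1-fold higher number from compound 1 to compound 4 (0.96 log units; beyond the scatter). Nothing available explains this reversal. The compounds shown leave open whether acetyl or methyl on the amine nitrogen, or ethoxy in place of methoxy, would follow compound 2 or compound 4.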